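Removing the isobutoxy group from a bis-chromone scaffold

The compounds below may be only part of what the source reports. "The series", "measured", "known", "first", "only" and "open" are said of these compounds alone.

Compounds measured so far:
- Compound 1, `CC(C)COc1cccc2occ(Cc3coc4ccccc4c3=O)c(=O)c12`: 1720 nM
- Compound 2, `COc1ccc2c(=O)c(Cc3coc4cccc(OCC5CCCCC5)c4c3=O)coc2c1`: 1120 nM
- Compound 3, `O=c1c(Cc2coc3cccc(OCC4CCCCC4)c3c2=O)coc2cc(O)ccc12`: 4250 nM

All three share a core of two fused ring systems joined by a single carbon, and each was tested in a functional assay on PC-3 cells (Homo sapiens) for antiproliferative activity, read by XTT assay; a higher number here means a weaker inhibitor, a lower number a stronger inhibitor. Compound 1 sits close to compound 2, their numbers lying within the usual scatter of each other, while the number for compound 3 lies clearly higher than that of compound 1.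

Among the measured compounds shown here, the only step between two measured compounds that differ in a single place is a 3.8-fold higher number from compound 2 to compound 3 (0.58 log units; beyond the scatter), where the loss of a small alkyl group from an oxygen weakened the inhibition.

Compound 4, `O=c1c(Cc2coc3ccccc3c2=O)coc2ccccc12`, removes the whole side chain from compound 1: hydrogen in place of isobutoxy on an aromatic carbon. This is a larger loss than the methyl removed between compound 2 and compound 3, so the expectation rests on that step, which is only a partial guide. A weakening in this assay is expected, and the step of a 2.9-fold higher number from compound 1 to compound 4 (0.46 log units; beyond the scatter) is the estimated outcome. Compound 4 is therefore expected to give about 5000 nM, in a range from 1500 nM to 20000 nM.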

Compound 4, half-maximal inhibitory concentration: 7400 nM
Estimate against measurement, compound 4: 1.5-fold (0.17 log units) below; the measured number falls inside the stated range.
By their numbers in this assay, from the lowest: compounds 2 and 1 (each within the scatter of the next); then compounds 3 and 4 (each within the scatter of the next).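

Replacing isobutoxy with hydrogen on this aromatic carbon gives a 4.3-fold higher number from compound 1 to compound 4 (0.63 log units; beyond the scatter) in this assay, so at this position the side chain makes a difference larger than the usual scatter. Among the compounds shown here, the only earlier step involved a methyl on an oxygen, so this is the first direct reading of what the isobutoxy group contributes; even without it, compound 4 still gives a measurable value of 7400 nM, which means the shared core alone retains some antiproliferative activity. Nothing measured here explains why the number rises.

From the compounds shown here alone, with only isobutoxy and hydrogen compared at this carbon, it remains open whether the effect depends on the particular chain. Going by these compounds, how a methoxy, a longer chain or an amine would compare in the same place also remains unknown.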